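Lengthening an Amino Acid Side Chain: an Expected Step

The source may hold more compounds than are shown below. What is called first, only, known or untested is meant among the compounds shown, and "the series" means these compounds.

Measured so far in a functional assay on MCF7 cells (Homo sapiens) for antiproliferative activity, read by MTT assay, with a stated time of 48 h; a lower number here means a stronger inhibitor, a higher number a weaker inhibitor:
Compound 1 `Cc1nc2ccccc2nc1Oc1ccc(C(=O)N[C@@H](C)C(=O)O)cc1` gives 25600 nM.
Compound 2 `CC[C@@H](C)[C@H](NC(=O)c1ccc(Oc2nc3ccccc3nc2C)cc1)C(=O)O` gives 35700 nM.
Compound 3 `C[C@H](NC(=O)c1ccc(Oc2nc3ccccc3nc2NC(C)(C)C)cc1)C(=O)O` gives 29400 nM.

All three numbers lie close together. Compound 2 differs from compound 1 in one place: sec-butyl in place of methyl on a saturated chain carbon bound to an amide-type nitrogen and a carbonyl carbon. That change made the step of a 1.4-fold higher number from compound 1 to compound 2 (0.14 log units; within the scatter). Compound 3 differs from compound 1 in its core: (tert-butyl)amino in place of methyl on an aromatic carbon. This change made the step of a 1.1-fold higher number from compound 1 to compound 3 (0.06 log units; within the scatter).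

Compound 4 `CC[C@@H](C)[C@H](NC(=O)c1ccc(Oc2nc3ccccc3nc2NC(C)(C)C)cc1)C(=O)O` has not yet been measured. It differs from compound 3 by sec-butyl in place of methyl on a saturated chain carbon bound to an amide-type nitrogen and a carbonyl carbon, and the place of the change reads word for word as it does between compound 1 and compound 2, so this is the same change, made now on the core of compound 3 instead of the core of compound 1.

Because the earlier step of a 1.4-fold higher number from compound 1 to compound 2 (0.14 log units; within the scatter) was small, and because the cores of compound 1 and compound 3 gave nearly the same number, as a 1.1-fold higher number from compound 1 to compound 3 (0.06 log units; within the scatter) shows, the step from compound 3 to compound 4 is expected to be of similar size, a 1.3-fold higher number from compound 3 to compound 4 (0.11 log units; within the scatter). This expectation rests on two pairs only, so a result anywhere within the usual scatter of compound 3 would not be surprising.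

Compound 4 is therefore estimated to give 38000 nM in this assay, most likely between 20000 nM and 75000 nM.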

Compound 4, half-maximal inhibitory concentration: 11400 nM
The estimate for compound 4 lay 3.3-fold (0.52 log units) above the measured number; measured number outside the range, below it.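

In this assay, putting sec-butyl in place of methyl on the core that carries (tert-butyl)amino gave a 2.6-fold lower number from compound 3 to compound 4 (0.41 log units; beyond the scatter), and this step did not match the one seen for the same change on the core that carries methyl: the same change on two cores in this assay, a 1.4-fold higher number (0.14 log units; within the scatter) from compound 1 to compound 2 and a 2.6-fold lower number (0.41 log units; beyond the scatter) from compound 3 to compound 4, 3.6-fold (0.56 log units) apart, beyond the scatter of two such steps. Read the other way, putting (tert-butyl)amino in place of methyl on an aromatic carbon, with sec-butyl already present on the chain, gave a 3.1-fold lower number from compound 2 to compound 4 (0.50 log units; beyond the scatter), and this step likewise differed from the one seen where the chain carries methyl: the same change on two cores in this assay, a 1.1-fold higher number (0.06 log units; within the scatter) from compound 1 to compound 3 and a 3.1-fold lower number (0.50 log units; beyond the scatter) from compound 2 to compound 4, 3.6-fold (0.56 log units) apart, beyond the scatter of two such steps. The two changes therefore do not simply add up in this set, so a step measured on one core was a poor guide to the other, but four compounds form a single such square and cannot show why this happens or whether it would recur with other groups.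

The compounds shown leave open whether a side chain of intermediate size, such as isopropyl, would give part of this step on the core of compound 3 or none of it. They also leave open whether a plain amino group or a smaller alkylamine, such as methylamino, in place of (tert-butyl)amino would behave in the same way with sec-butyl on the chain.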